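The source may report more compounds than this note shows. Statements on the series, on what has been measured and on what is new or still open speak of the compounds shown alone.

Of the compounds shown here, three sharing one core have been measured in a functional assay on CHO cells for antagonist activity at adenosine receptor A2b (Homo sapiens), read by 33P incorporation, with a stated time of 20 min; a lower number here means a stronger inhibitor, a higher number a weaker inhibitor. Compound 1 `CCCn1c(-c2ccccc2)nc2c(NC3CCC3)ncnc21` gives 774 nM. Compound 2 `CCCn1c(-c2ccccc2)nc2c(NC3CCCC3)ncnc21` gives 3430 nM, and compound 3 `CCCn1c(-c2ccccc2)nc2c(NC3CCCCC3)ncnc21` gives 5310 nM. Among these three, compound 2 stands second highest: the step of a 4.4-fold higher number from compound 1 to compound 2 (0.65 log units; beyond the scatter) lies beyond the scatter, whereas a 1.5-fold higher number from compound 2 to compound 3 (0.19 log units; within the scatter) lies within it, and a 6.9-fold higher number from compound 1 to compound 3 (0.84 log units; beyond the scatter) is the widest span seen. Every measured step changes only the saturated ring on the nitrogen on the aromatic ring, from cyclobutyl through cyclopentyl to cyclohexyl, while the propyl chain is kept the same throughout. Compound 4 `CCn1c(-c2ccccc2)nc2c(NC3CCCC3)ncnc21` differs from compound 2 by hydrogen in place of methyl on a saturated chain carbon, two bonds along the chain from an aromatic nitrogen. Among the compounds with values here, none of the measured steps touches this chain, so no measured step bears on the change, and the series gives no direct guide to its size or direction. With nothing to point either way, a shift within the scatter is expected, giving an estimated step of a 1.0-fold lower number from compound 2 to compound 4 (0.00 log units; within the scatter). Compound 4 is therefore expected to give about 3400 nM in this assay, with an estimated range from 1400 nM to 8500 nM.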

Compound 4, inhibition constant: 5790 nM
Compound 4: middle estimate off by 1.7-fold (0.23 log units), on the low side; low and high end bracket the measured number.
By their numbers in this assay, from the lowest: compound 1; then compounds 2, 3 and 4 (each within the scatter of the next).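

In this assay, within the data shown here, propyl to ethyl on the aromatic nitrogen gives a 1.7-fold higher number from compound 2 to compound 4 (0.23 log units; within the scatter), the first reading at this position. With cyclopentyl kept in place, removing this methyl leaves compound 2 and compound 4 indistinguishable, whereas the ring step a 4.4-fold higher number from compound 1 to compound 2 (0.65 log units; beyond the scatter) lies beyond the scatter. No measured evidence on this series explains the result.

Still open, going by these compounds, is whether a longer chain such as butyl, or a chain ending in an amine or a carboxylic acid, would also stay within the scatter at this position. Also open is whether the ethyl chain would read the same with cyclobutyl in place of cyclopentyl, since the chain step is shown only with cyclopentyl.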